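Hydrogen in Place of Trifluoromethyl: Compound 3 to Compound 4

The compounds below may be only part of what the source reports. "The series", "measured", "known", "first", "only" and "open" are said of these compounds alone.

Compound 1 `CN1CCN(c2cc(C(=O)Nc3ccc(C4=Nc5cscc5NC(=O)C4)cc3)cc(C(F)(F)F)c2)CC1` — in a functional assay on U-937 cells (Homo sapiens) for antiproliferative activity, read by MTT assay, with a stated time of 24 h (on this read-out higher numbers stand for weaker inhibition of growth and lower numbers for stronger inhibition of growth), compound 1 gives > 30000 nM, which is a limit of the assay rather than a number.
Compound 2 `O=C1CC(c2ccc(NC(=O)Nc3ccc(Cl)cc3)cc2)=Nc2cscc2N1` — in this assay compound 2 gives 964 nM.
Compound 3 `O=C1CC(c2cccc(NC(=O)Nc3ccc(Cl)c(C(F)(F)F)c3)c2)=Nc2cscc2N1` — in this assay compound 3 gives 14300 nM.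

Compound 3 holds the highest of the two numbers; its nearest neighbour, compound 2, sits far below it, well beyond the usual scatter. For compound 1 only a limit is known (the limit of > 30000 nM in this assay, at which 1 of the 3 values shown sits).

Compound 4 `O=C1CC(c2cccc(NC(=O)Nc3ccc(Cl)cc3)c2)=Nc2cscc2N1` is compound 3 with hydrogen in place of trifluoromethyl on an aromatic carbon. Among the measured compounds shown here, no measured pair shows this change on its own. Compound 2 also lacks the trifluoromethyl and sits much lower, yet it differs from compound 3 in a second place as well, so only part of that gap can be credited to the group. A moderate fall in the number is expected, a 2.9-fold lower number from compound 3 to compound 4 (0.46 log units; beyond the scatter). Compound 4 is therefore estimated at 5000 nM, within a range from 1200 nM to 20000 nM.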

Compound 4, concentration for 50% growth inhibition: 4550 nM
Estimate against measurement, compound 4: 1.1-fold (0.04 log units) above, within the range that was stated.
By their numbers in this assay, from the lowest: compound 2; then compound 4; then compound 3. At a limit, above all of these: compound 1.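

Among the compounds shown here, the pair compound 3 and compound 4 isolates a single change for the first time: in this assay, hydrogen in place of trifluoromethyl, on the aromatic carbon ortho to a chloro group, gives a 3.1-fold lower number from compound 3 to compound 4 (0.50 log units; beyond the scatter) and so shows that growth inhibition responds to what sits on this carbon. The group is not the whole story, since compound 4 gives 4550 nM while compound 2 gives 964 nM even though neither carries trifluoromethyl. Nothing measured here explains why the number falls with this change.

Still open, from the compounds shown here alone, is whether a methyl group or an amine on this same carbon would lower the number further or raise it again. Also open, going by these compounds, is whether adding trifluoromethyl to compound 2 would raise its number by a similar step.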